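The source may hold more compounds than are shown below. What is called first, only, known or untested is meant among the compounds shown, and "the series" means these compounds.

In a functional assay on UACC-257 cells (Homo sapiens) for inhibition, read by sulforhodamine B assay, with a stated time of 48 h (a higher number here means a weaker inhibitor of growth, a lower number a stronger inhibitor of growth), three compounds have been measured.
Compound 1, `Nc1cc(N)c2nc(-c3ccccc3)c(NCc3ccc(F)cc3)nc2c1`: 4270 nM.
Compound 2, `COc1ccc(CNc2nc3cc(N)cc(N)c3nc2-c2ccccc2)cc1`: 30200 nM.
Compound 3, `COc1ccc(Sc2nc3cc(N)cc(N)c3nc2-c2ccccc2)cc1`: < 100000 nM, which is a limit of the assay and not a number.

Compound 3 thus stands only at a limit (the limit of < 100000 nM in this assay, at which 1 of the 3 values shown sits); where it lies among the others cannot be read, and the step from compound 1 to compound 3 is likewise unreadable a step that the limit leaves unreadable from compound 1 to compound 3. Compound 4, `Nc1cc(N)c2nc(-c3ccccc3)c(Oc3ccc(F)cc3)nc2c1`, differs from compound 3 in one place: 4-fluorophenoxy in place of (4-methoxyphenyl)sulfanyl on an aromatic carbon. For the measured compounds named here, no measured step covers the change of linker, so that part is unknown. Going by the values given here, the one step that bears on it is the exchange of fluoro for methoxy, a 7.1-fold higher number from compound 1 to compound 2 (0.85 log units; beyond the scatter), a modest shift toward weaker growth inhibition when methoxy enters; here fluoro enters instead. Compound 4 is therefore expected at an estimated 20000 nM, with a range from 3000 nM to 100000 nM, an expected step that the limit leaves unreadable from compound 3 to compound 4.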

Compound 4, concentration for total growth inhibition: 42700 nM
The estimate for compound 4 lay 2.1-fold (0.33 log units) below the measured number, within the range that was stated.
By their numbers in this assay, from the lowest: compound 1; then compounds 2 and 4 (each within the scatter of the next).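

In this assay, 4-fluorophenoxy in place of (4-fluorobenzyl)amino next to the ring nitrogen gives a 10-fold higher number from compound 1 to compound 4 (1.00 log units; beyond the scatter), a weaker inhibitor of growth. For the compounds shown here, this is the first readable change of how the aromatic ring is attached at this carbon, with the fluoro kept; the earlier readable step only exchanged the fluoro for methoxy. The step between compound 3 and compound 4 cannot be read: the limit of < 100000 nM in this assay, at which 1 of the 4 values shown sits.

Going by these compounds, whether the weakening follows the linking atom or the length of the link stays open. A 4-fluorophenylamino or a 4-fluorobenzyloxy group at this carbon would separate the two.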